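The source may hold more compounds than are shown below. What is called first, only, known or untested is meant among the compounds shown, and "the series" means these compounds.

Of the compounds shown here, three have so far been measured in a functional assay on the whole organism (strain Swiss albino) with Mus musculus as the target, with stated times of 30 min and 10 min, at a dose of 50 mg/kg by the oral route; a lower number here means less inhibition, a higher number more inhibition at the dose given (going by the name of the read-out). Compound 1 `CC(=O)c1c(NNc2nc(-c3ccccc3)cs2)cc(C)oc1=O` gives 51.4%, compound 2 `CC(=O)c1c(NNc2nc(C)cc(C)n2)cc(C)oc1=O` gives 64.9%, and compound 3 `Cc1cc2nn(-c3ccccc3)c(C)c2c(=O)o1` gives 50.2%. Among these three numbers compound 3 stands lowest; its nearest neighbour is compound 1, whose number lies within the usual scatter of it, while compound 2 lies furthest away, beyond the scatter. No two of the measured compounds differ from each other in one place only, so no single structural step can be read off among them.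

The account now turns to compound 4 `Cc1cc2nn(-c3ccc(Cl)cc3)c(C)c2c(=O)o1`, which has not yet been measured in this assay. It differs from compound 3 in a single respect: chloro in place of hydrogen on an aromatic carbon. Among the compounds with values here, with no measured step of this kind to draw on, the expectation rests on where compound 3 stands alone. Because compound 3 gives 50.2% in this assay, compound 4 is expected to land close to it, with an expected step of a number 0.2 percentage points lower from compound 3 to compound 4 (within the scatter) that should stay within the scatter, in neither direction clearly. The estimate for compound 4 in this assay is therefore 50%, with a range from 38% to 62%.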

Compound 4, a percentage reported as inhibition, in the whole organism at one dose (the size of the read-out at that dose, not a potency): 65.3%
The estimate for compound 4 lay 15.3 percentage points below the measured number; measured number outside the range, above it.
By their numbers in this assay, from the lowest: compounds 3 and 1 (each within the scatter of the next); then compounds 2 and 4 (each within the scatter of the next).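

Chloro in place of hydrogen on an aromatic carbon of the six-membered aromatic ring of carbon only, para to a large group, gives a number 15.1 percentage points higher from compound 3 to compound 4 (beyond the scatter) in this assay. Within the data shown here, this is the first single structural step that can be read, and it shows that this position is not indifferent to substitution: one heavy atom, with no ring, no hydrogen-bond donor or acceptor and no net charge, is enough to carry the number beyond the scatter. Nothing available here bears on why the number moves in this way.

The compounds shown leave open whether the step belongs to chloro itself or would also appear with fluoro, a methoxy group or an amine in the same place, and whether chloro on another carbon of that ring would give a similar step. Since the read-out is taken at a single dose, they also leave open how compound 3 and compound 4 would compare at other doses.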